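Bromo in place of trifluoromethyl: expected permeability

This account rests on a few compounds, and the source may have more. Where it says the series, first, only, none or still open, it means among the compounds named here.

compound 1 `FC(F)(F)c1ccc(NC2=NCCC3(CCCCC3)S2)cc1`: 3.06 10^-6 cm/s
compound 2 `CC(=O)c1cccc(NC2=NCCC3(CCCCC3)S2)c1`: 74.7 10^-6 cm/s
compound 3 `CC(C)c1ccc(NC2=NCCC3(CCCCC3)S2)cc1`: 15.7 10^-6 cm/s

Of the compounds shown here, three sharing one core have been measured in a physicochemical assay for permeability; a higher number here means that the compound crosses the layer faster, a lower number that the compound crosses the layer more slowly. Compound 1 stands lowest of the three: compound 3 lies nearest and compound 2 furthest. Among the compounds with values here, the only measured step that alters a single place, a 5.1-fold higher number from compound 1 to compound 3 (0.71 log units; beyond the scatter), went up. Compound 4 `Brc1ccc(NC2=NCCC3(CCCCC3)S2)cc1` differs from compound 1 in one place as well: bromo in place of trifluoromethyl on an aromatic carbon. Within the data shown here, no measured step swaps trifluoromethyl for bromo, so the step from compound 1 to compound 3 is the only guide, and a loose one. A modest rise is therefore expected, a 2.6-fold higher number from compound 1 to compound 4 (0.42 log units; beyond the scatter), with wide uncertainty on either side. For compound 4 the estimated value is 8 10^-6 cm/s, in a range from 2.5 10^-6 cm/s to 25 10^-6 cm/s.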

Compound 4, apparent permeability: 90.3 10^-6 cm/s
Estimate against measurement, compound 4: 11-fold (1.05 log units) below, outside the stated range (above it).
By their numbers in this assay, from the lowest: compound 1; then compound 3; then compounds 2 and 4 (each within the scatter of the next).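

At this aromatic carbon, the choice of group alone moves the number in this assay a long way: bromo in place of trifluoromethyl gives a 30-fold higher number from compound 1 to compound 4 (1.47 log units; beyond the scatter) and bromo in place of isopropyl gives a 5.8-fold higher number from compound 3 to compound 4 (0.76 log units; beyond the scatter). Among these three groups, trifluoromethyl therefore gives the lowest number, isopropyl the next and bromo the highest, with each step beyond the scatter. Nothing measured here explains this order. Still open, from the compounds shown here alone, is where chloro, an amine or a carboxylic acid at the same place would fall, and whether the order holds on another core.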